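The compounds below may be only part of what the source reports. "The series", "measured", "known", "first", "only" and "open" are said of these compounds alone.

Compound 1 `CC1=C(C(=O)Nc2ccc(F)cc2)C(c2ccc([N+](=O)[O-])cc2)N=C(SCc2ccccc2Cl)N1`: 15.9%
Compound 2 `CC1=C(C(=O)Nc2ccc(F)cc2)C(c2ccc([N+](=O)[O-])cc2)N=C(SCc2cccc(Cl)c2)N1`: 15.9%
Compound 3 `CC1=C(C(=O)Nc2ccc(F)cc2)C(c2ccc([N+](=O)[O-])cc2)N=C(SCc2ccc(Cl)cc2)N1`: 33.3%

In a functional assay on the whole organism (artery, strain albino) with Rattus norvegicus as the target, with a stated time of 240 min, at a dose of 10 mg/kg by the oral route (a higher number here means more inhibition at the dose given (going by the name of the read-out), a lower number less inhibition), compound 3 stands highest of the three measured numbers. The steps of a number 17.4 percentage points higher from compound 1 to compound 3 (beyond the scatter) and a number 17.4 percentage points higher from compound 2 to compound 3 (beyond the scatter) both lie beyond the scatter, whereas no change at the digits printed from compound 1 to compound 2 (within the scatter). Compound 4 `CC1=C(C(=O)Nc2ccc(F)cc2)C(c2ccc([N+](=O)[O-])cc2)N=C(SCc2ccc(F)cc2)N1` differs from compound 3 in one place: fluoro in place of chloro on an aromatic carbon. For the measured compounds named here, every measured step moved the chloro substituent around the benzyl ring; none exchanged one halogen for another, so no measured step bears directly on this change, and the direction of any effect cannot be read from the data. A step of about no size beyond the scatter is therefore expected, with wide uncertainty. Compound 4 is expected to give 28%, within 12% to 44%. The expected step is a number 5.3 percentage points lower from compound 3 to compound 4 (within the scatter).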

Compound 4, a percentage reported as inhibition, in the whole organism at one dose (the size of the read-out at that dose, not a potency): 25.6%
For compound 4 the middle estimate is 2.4 percentage points above the measured one; measured number inside the range.
By their numbers in this assay, from the lowest: compounds 1, 2, 4 and 3 (each within the scatter of the next, the first and the last beyond it).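

Fluoro in place of chloro at this position, on an aromatic carbon para to a large group, gives a number 7.7 percentage points lower from compound 3 to compound 4 (within the scatter) in this assay and so leaves the two halogens unseparated here. Compound 4 also gives a number 9.7 percentage points higher from compound 2 to compound 4 (within the scatter) and a number 9.7 percentage points higher from compound 1 to compound 4 (within the scatter) in the same assay, so the clear gap seen between compound 3 and those two chloro isomers does not appear for the fluoro compound. No measurement here explains these numbers. Still open, as far as these compounds go, is how a bromo, methoxy or amino group would read at this position.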